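From hydroxycyclobutyl to aminoazetidinyl on a shared core

The source may hold more compounds than are shown below. What is called first, only, known or untested is meant among the compounds shown, and "the series" means these compounds.

Two compounds frame the account, compound 1 `Nc1nc(-n2cc(C(=O)O)c(=O)c3cc(F)c([C@H]4C[C@H](O)C4)c(Cl)c32)c(F)cc1F` and compound 2 `Nc1nc(-n2cc(C(=O)O)c(=O)c3cc(F)c([C@H]4C[C@@H](O)C4)c(Cl)c32)c(F)cc1F`. In an ADME assay on microsomes from liver (Homo sapiens) for metabolic stability (a higher number here means faster removal of the compound, a lower number slower removal), compound 1 gives < 5 mL.min-1.g-1, which is a limit of the assay and not a number. In this assay compound 2 gives < 5 mL.min-1.g-1, again only a limit. Compound 2 therefore has no exact position, and the record shows (the limit of < 5 mL.min-1.g-1 in this assay, at which 2 of the 2 values shown sit). Between the pair lies a step that the two limits leave unreadable from compound 1 to compound 2, and what separates them structurally is the fact that compounds 1 and 2 differ only in the configuration as drawn.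

Compound 3 `Nc1nc(-n2cc(C(=O)O)c(=O)c3cc(F)c(N4CC(N)C4)c(Cl)c32)c(F)cc1F` departs from compound 2 in a different way: 3-aminoazetidin-1-yl in place of 3-hydroxycyclobutyl on an aromatic carbon. In words, 3-aminoazetidin-1-yl stands in place of 3-hydroxycyclobutyl on an aromatic carbon, ortho to a chloro group and ortho to a fluoro group. Within the data shown here, no measured step covers this exchange, and the one step available has no readable size to carry over. The expectation rests only on (the limit of < 5 mL.min-1.g-1 in this assay, at which 2 of the 2 values shown sit). No step beyond the scatter is expected in this assay, and the estimated change is a step that the limit leaves unreadable from compound 2 to compound 3. For compound 3 the estimate is 4 mL.min-1.g-1, with an expected range from 2 mL.min-1.g-1 to 9 mL.min-1.g-1.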

Compound 3, intrinsic clearance in microsomes in the Homo sapiens assay: < 5 mL.min-1.g-1
Compound 3: no number, only a limit; the forecaster's own chance of this, stated with the estimate: 70%; the middle value is on the limit's open side.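

In the Homo sapiens assay compound 3 gives < 5 mL.min-1.g-1, which is a limit of the assay and not a number.

In the Homo sapiens assay no step from compound 1 or compound 2 to compound 3 can be read, and the values shown share one limit: the limit of < 5 mL.min-1.g-1 in the Homo sapiens assay, at which 3 of the 3 values shown sit.

In a physicochemical assay for acid dissociation, compound 2 gives 4.96, and compound 3 gives 5.33. In the physicochemical assay this is a number 0.37 log units higher from compound 2 to compound 3 (beyond the scatter).

The compounds shown leave open whether compound 1, compound 2 and compound 3 differ at all in the Homo sapiens assay, and by how much.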